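The source may hold more compounds than are shown below. What is called first, only, known or untested is meant among the compounds shown, and "the series" means these compounds.

Measured in a functional assay on MT4 cells (Homo sapiens) for cytotoxicity; a lower number here means that less compound is tolerated, a higher number that more compound is tolerated:
Compound 1 `CC(C)Sc1nc(O)cc(C(C)c2c(F)cccc2F)n1`: 167000 nM
Compound 2 `CC(C)CSc1nc(O)cc(C(C)c2c(F)cccc2F)n1`: > 200000 nM

Compound 2 has no exact number in this assay. Its reading of > 200000 nM is a limit of the assay and not a number, and it is the case described by the limit of > 200000 nM in this assay, at which 1 of the 2 values shown sits.

The next compound, compound 3 `CCC(C)Sc1nc(O)cc(C(C)c2c(F)cccc2F)n1`, has not yet been measured. It keeps the shared core of compound 2 and has sec-butyl in place of isobutyl on a sulfur. The two compounds have the same atoms, joined differently.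

For the measured compounds named here, only one measured step bears on this change: an at least 1.1-fold higher number from compound 1 to compound 2 (0.07 log units; that floor lies within the scatter). That step, with isobutyl in place of isopropyl on a sulfur, changed the group at the same place, and its floor stays within the scatter. On this single step, no change beyond the scatter is expected in this assay, although the limit on compound 2 leaves the true size of any step open.

The expected step is an at least 1.0-fold lower number from compound 2 to compound 3 (0.03 log units; that floor lies within the scatter). For compound 3 the estimated value is 185000 nM, with an expected range from 110000 nM to 260000 nM.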

Compound 3, half-maximal cytotoxic concentration: > 200000 nM
Compound 3: only a limit was reported (the forecaster's own chance of this, stated with the estimate: 50%); middle value at least 1.0-fold (0.03 log units) away from the limit.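

In this assay compound 3 reads > 200000 nM, which is a limit of the assay and not a number. Isobutyl and sec-butyl on the sulfur therefore both end at the same limit, so a second branched chain at this position has given no exact reading, and the result for compound 2 no longer stands alone: the limit of > 200000 nM in this assay, at which 2 of the 3 values shown sit. The one step that can be read is an at least 1.1-fold higher number from compound 1 to compound 3 (0.07 log units; that floor lies within the scatter), so methyl in place of hydrogen on a saturated chain carbon, two bonds along the chain from a sulfur, gives a floor with no change beyond the scatter, while the step between the two limits cannot be read.

Where the true values of compound 2 and compound 3 lie, and whether the two differ at all, stays open. Also open, as far as these compounds go, is whether a longer chain such as n-hexyl, or a ring such as cyclohexyl, on the sulfur would return an exact number in this assay.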